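A few compounds are considered here, and "the series" means these few. Any claim that something is new, unique, unknown or untested is made for them only; others in the source may bear on it.

Compound 3 `Cn1c(N2CCCC2)c(C#N)c2c(N)ncnc21` gives 41 nM in an assay on isolated protein for binding affinity to Leucine-rich repeat serine/threonine-protein kinase 2 (Homo sapiens), read by TR-FRET and LanthaScreen, with a stated time of 2 h (a lower number here means a stronger inhibitor, a higher number a weaker inhibitor), the highest of the three numbers measured. Compound 1 `Cc1c(Nc2nc(N)c3c(C#N)c(N4CCC[C@H]4C)n(C)c3n2)cnn1C` gives 2 nM and compound 2 `C[C@@H]1CCCN1c1c(C#N)c2c(N)nc(Nc3cn[nH]c3)nc2n1C` gives 0.2 nM, so compound 3 sits well above both. Among the measured compounds shown here, the only step measured, a 10-fold lower number from compound 1 to compound 2 (1.00 log units; beyond the scatter), concerns the group on the ring nitrogen and leaves the pyrrolidin-1-yl untouched, so no measured step bears directly on the change to compound 4 `CN(C)c1c(C#N)c2c(N)ncnc2n1C`, which is dimethylamino in place of pyrrolidin-1-yl on an aromatic carbon. With nothing in the data to anchor it, a modest step is expected, more likely toward a higher number than a lower one. The expected step is a 2.0-fold higher number from compound 3 to compound 4 (0.29 log units; within the scatter). For compound 4 the estimated value is 80 nM, within a range from 25 nM to 300 nM.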

Compound 4, inhibition constant: 111 nM
Compound 4: the middle estimate sits 1.4-fold (0.14 log units) below what was measured; low and high end bracket the measured number.
By their numbers in this assay, from the lowest: compound 2; then compound 1; then compound 3; then compound 4.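

In this assay replacing pyrrolidin-1-yl with dimethylamino gives a 2.7-fold higher number from compound 3 to compound 4 (0.43 log units; beyond the scatter) and so shows that this aromatic carbon is sensitive to the amine it carries, even though the step is modest. The ring form is the better of the two here, while the other measured step concerns a different place. The data offer no reason for this difference. On these data alone, whether the step holds on the cores of compound 1 and compound 2 stays open. So does how a piperidine, a morpholine or an azetidine would fare at this carbon.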